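Compound 1 and its oxolan-2-yl counterpart

The source may hold more compounds than are shown below. What is called first, only, known or untested is meant among the compounds shown, and "the series" means these compounds.

Compound 1 `COc1cc(CNCc2ccccc2)ccc1OCc1ccc(Cl)nc1` gives 90000 nM
Compound 2 `COc1cc(CNCc2ccncc2)ccc1OCc1ccccc1F` gives 5100 nM
Compound 3 `COc1cc(CNCc2ccncc2)ccc1OCc1cccc(F)c1` gives 4800 nM

In a functional assay on HeLa cells (Homo sapiens) for inhibition, with a stated time of 72 h (on this read-out lower numbers stand for an effect already at smaller amounts and higher numbers for an effect only at larger amounts of compound), compound 1 stands highest at 90000 nM and lies beyond the scatter from both other compounds. Compound 4 `COc1cc(CNCC2CCCO2)ccc1OCc1ccc(Cl)nc1` keeps the core of compound 1 but carries oxolan-2-yl in place of phenyl on a saturated chain carbon bound to an amine nitrogen, a difference counted as oxolan-2-yl in place of phenyl on a saturated chain carbon bound to an amine nitrogen and not yet tested. For the measured compounds named here, the only measured step is a 1.1-fold lower number from compound 2 to compound 3 (0.03 log units; within the scatter) and it stays within the scatter. It does not touch this place, so the data give no direction and no shift beyond the scatter is expected in this assay here. The expected size is a 1.3-fold lower number from compound 1 to compound 4 (0.11 log units; within the scatter) and that remains within the scatter. Compound 4 is estimated at 70000 nM with an expected range from 18000 nM to 200000 nM as its likely span.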

Compound 4, half-maximal effective concentration: 66000 nM
Beside the measured number, compound 4's estimate is 1.1-fold (0.03 log units) above it; the measured number falls inside the stated range.
By their numbers in this assay, from the lowest: compounds 3 and 2 (each within the scatter of the next); then compounds 4 and 1 (each within the scatter of the next).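

In this assay the exchange of phenyl for oxolan-2-yl on a saturated chain carbon bound to an amine nitrogen amounts to a 1.4-fold lower number from compound 1 to compound 4 (0.13 log units; within the scatter) and so moves the number no further than the scatter. For the compounds shown here, this is the first reading at this place, and it shows that an aromatic carbon ring can give way to a non-aromatic five-membered ring with one hydrogen-bond acceptor without a clear shift. No measurement shown offers a reason for this. As far as these compounds go, it remains open whether a carboxylic acid, a second amine or a longer chain at this place would shift the number beyond the scatter.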